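A few compounds are considered here, and "the series" means these few. Any claim that something is new, unique, unknown or untested is made for them only; others in the source may bear on it.

Measured compounds:
- compound 1 `NC(=O)c1c(NC(=O)c2ccccc2Cl)sc2c1CCN(Cc1ccc([N+](=O)[O-])cc1)C2`: 11400 nM
- compound 2 `NC(=O)c1c(NC(=O)c2ccc(C(F)(F)F)cc2)sc2c1CCN(Cc1ccc(Cl)cc1)C2`: limit, > 50000 nM
- compound 3 `NC(=O)c1c(NC(=O)c2ccccc2F)sc2c1CCN(Cc1cccc(Cl)c1)C2`: 19800 nM

The read-out is a functional assay on HL-60 cells (Homo sapiens) for antiproliferative activity, with a stated time of 24 h; on this read-out lower numbers stand for stronger inhibition and higher numbers for weaker inhibition. In this assay compound 1 gives 11400 nM, the lowest of the two numbers that are actual numbers. Compound 3 gives 19800 nM in this assay, and the gap between compound 1 and compound 3 lies within the scatter, so the two cannot be ordered. For compound 2 this assay reports only a limit, > 50000 nM, and not a number; the account notes (the limit of > 50000 nM in this assay, at which 1 of the 3 values shown sits).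

The step to be followed leads from compound 1 to compound 4 `CSc1ccccc1NC(=S)N1CCc2c(sc(NC(=O)c3ccccc3Cl)c2C(N)=O)C1`. The change is a group of 11 heavy atoms (8 carbon, 1 nitrogen, 2 sulfur; one six-membered aromatic ring of carbon only) in place of a group of 10 heavy atoms (7 carbon, 1 nitrogen, 2 oxygen; one six-membered aromatic ring of carbon only), on an amine nitrogen in a ring. For the measured compounds named here, no step between two measured compounds isolates this kind of change, so nothing measured tells which way it should go. The expected step of a 1.1-fold higher number from compound 1 to compound 4 (0.02 log units; within the scatter) is therefore none beyond the scatter. On that basis compound 4 is estimated to give 12000 nM in this assay, with a range from 3000 nM to 50000 nM.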

Compound 4, half-maximal inhibitory concentration: 14600 nM
Compound 4: middle estimate off by 1.2-fold (0.09 log units), on the low side; measured number inside the range.
By their numbers in this assay, from the lowest: compounds 1, 4 and 3 (each within the scatter of the next). At a limit, above all of these: compound 2.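

In this assay, putting the group with no common name in place of 4-nitrobenzyl, on an amine nitrogen in a ring, gives a 1.3-fold higher number from compound 1 to compound 4 (0.11 log units; within the scatter) and is the first step shown at this position. The earlier compounds shown here held no pair differing in this place alone, and this step shows that the read-out can stay within the scatter when a group carrying two sulfur atoms and a hydrogen-bond donor takes the place of the nitro-bearing benzyl group on the core of compound 1. Nothing measured here gives a reason for this result.

As far as these compounds go, whether an amine, a carboxylic acid or a longer chain on the same ring nitrogen would move the number beyond the scatter stays open. From the compounds shown here alone, it is also open whether this change would give a similar step with the other amide groups seen in compound 2 and compound 3.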